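The source may report more compounds than this note shows. Statements on the series, on what has been measured and on what is new or still open speak of the compounds shown alone.

Compound 1: `CC(C)(C)c1ccc(NC(=O)c2cc(=O)[nH]c3cc(Br)ccc23)cc1`, giving > 20000 nM.
Compound 2: `COc1ccc(-c2ccc3c(C(=O)Nc4cccc(F)c4)cc(=O)[nH]c3c2)cc1`, giving > 20000 nM.

Of the compounds shown here, two have so far been tested in a functional assay on KYSE-70 cells for antiproliferative activity against KYSE-70 cell line (Homo sapiens), read by MTT assay, with a stated time of 72 h; a lower number here means a stronger inhibitor, a higher number a weaker inhibitor. For compound 1 the result is a limit of the assay rather than a number, > 20000 nM. For compound 2 the result is likewise a limit, > 20000 nM. Compound 2 therefore stands at the edge of what this assay reports, and the note the limit of > 20000 nM in this assay, at which 2 of the 2 values shown sit, shows that both measured values sit there, so no order between compound 1 and compound 2 can be drawn.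

Compound 3, `C=Cc1ccc2c(C(=O)Nc3cccc(F)c3)cc(=O)[nH]c2c1`, remains to be measured in this assay. It differs from compound 2 in one place: vinyl in place of 4-methoxyphenyl on an aromatic carbon. Within the data shown here, no step between measured compounds is available, so there is no measured guide to the size of this change. In this assay the expected step is a step that the limit leaves unreadable from compound 2 to compound 3, that is, none beyond the scatter. Compound 3 is estimated at 25000 nM, with a range from 5000 nM to 100000 nM, and is expected most likely to be reported again only as a limit.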

Compound 3, half-maximal inhibitory concentration: 9700 nM
Compound 3: the middle estimate sits 2.6-fold (0.41 log units) above what was measured, and the stated range covers the measured number.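

At this place, an aromatic carbon of a six-membered aromatic ring of carbon only that is part of a fused system of two rings, vinyl in place of 4-methoxyphenyl brings a reading that is a number in this assay: compound 3 gives 9700 nM. The change amounts to an at least 2.0-fold lower number from compound 2 to compound 3 (0.31 log units; beyond the scatter), which shows that the number in this assay responds to the group held at this place, with the lower number going with vinyl, which has no ring. The true size of the step cannot be read, and what is printed is only a bound on it: the limit of > 20000 nM in this assay, at which 2 of the 3 values shown sit.

The one step removes a ring and brings in a double bond together, and the compounds shown do not tell which of the two goes with the lower number. As far as these compounds go, whether an ethyl group, an unsubstituted phenyl ring or an amine at this place would give a lower number in this assay stays open, as does how compound 1, which differs from compound 3 in more than one place, relates to this step.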